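The compounds below may be only part of what the source reports. "The series", "measured", "known", "first", "only" and "open" are said of these compounds alone.

The series is followed in an ADME assay on HEL cells (Homo sapiens) for cytotoxicity (on this read-out lower numbers stand for higher toxicity in this test and higher numbers for lower toxicity in this test), where three compounds have been measured. Compound 1, with the structure `[O-]c1on[n+](-c2ccc(Cc3ccc(-[n+]4noc([O-])c4CN4CCN(c5ccccc5)CC4)cc3)cc2)c1CN1CCN(c2ccccc2)CC1`, returns only a limit of the assay, >= 20 ug/mL; this is recorded as the limit of >= 20 ug/mL in this assay, at which 1 of the 3 values shown sits. Compound 2, with the structure `Cc1ccc(-[n+]2noc([O-])c2CN2CCN(c3cccc(Cl)c3)CC2)cc1`, gives 100 ug/mL in this assay. Compound 3, with the structure `Cc1ccc(-[n+]2noc([O-])c2CN2CCN(C)C(c3ccccc3)C2)cc1`, gives 100 ug/mL in this assay. Compound 2 therefore stands level with compound 3 at the digits reported, and the two are not separated beyond the usual scatter of this assay, so no order can be drawn between them. Going by the values given here, no pair among the measured compounds differs in a single place, so no measured step is available.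

The unmeasured compound 4, with the structure `CC(=O)N1CCN(Cc2c([O-])on[n+]2-c2ccc(C)cc2)CC1`, differs from compound 2 in one place: acetyl in place of 3-chlorophenyl on an amine nitrogen in a ring. Among the compounds with values here, for this change the writer expects no step beyond the scatter in this assay, in either direction, since the only two numbers known, from compound 2 and compound 3, sit at the same level despite their different substituents on the piperazine ring. The step from compound 2 to compound 4 is accordingly estimated as no change at the digits printed from compound 2 to compound 4 (within the scatter). Compound 4 is expected to give about 100 ug/mL in this assay, with a plausible range from 50 ug/mL to 200 ug/mL.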

Compound 4, minimum cytotoxic concentration: 100 ug/mL
Compound 4: middle estimate and measured number agree at the digits printed, and the stated range covers the measured number.
By their numbers in this assay, from the lowest: compounds 2, 3 and 4 (each within the scatter of the next).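

In this assay, going by these compounds alone, acetyl in place of 3-chlorophenyl on an amine nitrogen in a ring brings no change at the digits printed from compound 2 to compound 4 (within the scatter), and this is the first measured step at this position. The exchange is not a small one in structural terms: the group that leaves carries a six-membered aromatic ring of carbon only, while the acetyl that enters has no ring, is the smaller group by heavy atoms, and brings a hydrogen-bond acceptor and a double bond outside aromatic rings. Even so, this one pair shows that the read-out on this nitrogen can stay level across two very different groups, which the earlier compounds, with no pair differing in one place, could not show.

As far as these compounds go, whether an amine, a carboxylic acid or a longer chain on this same nitrogen would also stay level remains open, as does any change elsewhere on the shared core. The reading of compound 1 is a limit, not a number, so it offers no further comparison: the limit of >= 20 ug/mL in this assay, at which 1 of the 4 values shown sits.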